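Restoring a Trifluoromethyl Carbinol on the Shared Core

The source may hold more compounds than are shown below. What is called first, only, known or untested is meant among the compounds shown, and "the series" means these compounds.

Compound 1 `CC#C[C@H]1CN(S(=O)(=O)c2ccc(N)nc2)CCN1c1ccc(C(O)(COC)C(F)(F)F)cc1`: 202 nM
Compound 2 `CC#C[C@H]1CN(S(=O)(=O)c2ccc(N)nc2)CCN1c1ccc(C(=O)NC)cc1`: 4050 nM

In an assay on cells (Hepatocyte) for inhibition of glucokinase regulatory protein (Mus musculus), with stated times of 20 min and 40 min (a lower number here means that less compound is needed, a higher number that more compound is needed for the effect), compound 2 gives 4050 nM, the highest of the two numbers measured, while compound 1 gives 202 nM. Compound 3 `CC#C[C@H]1CN(S(=O)(=O)c2ccc(N)nc2)CCN1c1ccc(C(O)(CC#N)C(F)(F)F)cc1` differs from compound 2 by a group of 9 heavy atoms (4 carbon, 1 nitrogen, 1 oxygen, 3 fluorine; no ring) in place of a group of 4 heavy atoms (2 carbon, 1 nitrogen, 1 oxygen; no ring), on an aromatic carbon. Going by the values given here, only one measured step bears on this change, and it runs the opposite way: compound 1 carries a group of equal size with the same trifluoromethyl and hydroxyl, and a 20-fold higher number from compound 1 to compound 2 (1.30 log units; beyond the scatter) was large. Reversing that step, compound 3 is expected to show a 16-fold lower number from compound 2 to compound 3 (1.21 log units; beyond the scatter), a large move to lower numbers, with an estimated value of 250 nM in a range from 80 nM to 800 nM.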

Compound 3, half-maximal effective concentration: 219 nM
Compound 3: the middle estimate sits 1.1-fold (0.06 log units) above what was measured; measured number inside the range.
By their numbers in this assay, from the lowest: compounds 1 and 3 (each within the scatter of the next); then compound 2.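

A step of an 18-fold lower number from compound 2 to compound 3 (1.27 log units; beyond the scatter) in this assay shows that a second trifluoromethyl carbinol in place of methylcarbamoyl also gives a large move to a lower number. Cyano and methoxy on the saturated chain carbon cannot be told apart, at a 1.1-fold higher number from compound 1 to compound 3 (0.04 log units; within the scatter) in this assay so the large step away from methylcarbamoyl does not rest on the methoxy alone. No measurement given here accounts for either step. On these data alone, it remains open whether an amine, a carboxylic acid or a longer chain on that carbon would stay level with cyano and methoxy, and whether the hydroxyl or the trifluoromethyl carries the step.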